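This account rests on a few compounds, and the source may have more. Where it says the series, first, only, none or still open, it means among the compounds named here.

Of the compounds shown here, two have been tested in a functional assay on the whole organism for inhibition, with Mus musculus as the target, with a stated time of 1 h, at a dose of 50 mg/kg by the oral route; on this read-out higher numbers stand for more inhibition at the one dose given (going by the name of the read-out) and lower numbers for less inhibition. Compound 1 `Cc1ccc(-c2c(S(=O)(=O)c3ccccc3)cnc3cc(C)nn23)cc1` gives 25.8% in this assay. Compound 2 `O=S(=O)(c1ccccc1)c1cnc2cc(-c3ccc(Cl)cc3)nn2c1-c1ccc(Br)cc1` gives 24.2% in this assay, which is the lower of the two numbers, though the gap to compound 1 lies within the usual scatter of such measurements, so the two cannot be told apart on these data.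

The next compound, compound 3 `Cc1cc2ncc(S(=O)(=O)c3ccccc3)c(-c3ccc(Br)cc3)n2n1`, has not yet been measured in this assay. It differs from compound 2 in one place: methyl in place of 4-chlorophenyl on an aromatic carbon. Within the data shown here, no step between two measured compounds isolates this particular change, so there is no direct guide to its effect. What can be said is that compound 1 and compound 2, which differ in several places at once, give numbers that sit within the scatter of each other, and nothing in the data points to either direction for compound 3.

The step from compound 2 to compound 3 is therefore expected to be a number 0.8 percentage points higher from compound 2 to compound 3 (within the scatter), a size that does not go beyond the scatter. Compound 3 is estimated to give 25% in this assay. The expected range for compound 3 runs from 10% to 40%.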

Compound 3, a percentage reported as inhibition, in the whole organism at one dose (the size of the read-out at that dose, not a potency): 7.4%
Beside the measured number, compound 3's estimate is 17.6 percentage points above it, and the stated range ends above it.
By their numbers in this assay, from the lowest: compound 3; then compounds 2 and 1 (each within the scatter of the next).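

In this assay, among these compounds, methyl in place of 4-chlorophenyl on an aromatic carbon of the five-membered ring gives a number 16.8 percentage points lower from compound 2 to compound 3 (beyond the scatter) and is a step beyond the scatter, so the first single-change reading at this position shows that the group there does matter. Compound 3 also differs in one place from compound 1, and bromo in place of methyl on an aromatic carbon gives a number 18.4 percentage points lower from compound 1 to compound 3 (beyond the scatter) as a second step beyond the scatter, which places compound 3 below both of its neighbours. Nothing measured here explains either step.

These two steps do not show whether the loss at the first position comes from removing the ring or the chlorine, and a plain phenyl or a longer chain such as butyl at that carbon would help separate the two. On these data alone, it also remains open whether bromo in place of methyl would give a similar step with 4-chlorophenyl in place of methyl on the five-membered ring, or whether an amine there would fit either trend.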